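Fluoro to methoxy on two related cores: cytotoxicity outlook

This account rests on a few compounds, and the source may have more. Where it says the series, first, only, none or still open, it means among the compounds named here.

Four compounds are compared here, each carrying two nitrile-bearing rings around a shared central piece. Compound 1 `N#Cc1ccc(Nc2nccc(Nc3ccc(-c4ccc(C#N)cc4)cc3F)n2)cc1` and compound 3 `COc1cc(-c2ccc(C#N)cc2)ccc1Nc1ccnc(Nc2ccc(C#N)cc2)n1` share one core; compound 2 `N#Cc1ccc(Nc2nccc(Oc3ccc(-c4ccc(C#N)cc4)cc3F)n2)cc1` and compound 4 `COc1cc(-c2ccc(C#N)cc2)ccc1Oc1ccnc(Nc2ccc(C#N)cc2)n1` share another. The difference between the two cores is not broken down here.

All were, or will be, tested in a functional assay on MT4 cells (Homo sapiens) for cytotoxicity, read by MTT assay, with a stated time of 5 days; on this read-out higher numbers stand for lower toxicity in this test and lower numbers for higher toxicity in this test. Compound 1 gives 308000 nM in this assay. For compound 3 the result is only a limit of the assay, > 298000 nM. For compound 2 the result is likewise only a limit, > 307000 nM.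

The change from compound 1 to compound 3 is methoxy in place of fluoro on an aromatic carbon. Its size cannot be read, as a step that the limit leaves unreadable from compound 1 to compound 3 shows; this follows from the limit of > 298000 nM in this assay, at which 1 of the 3 values shown sits. The same change, (methoxy in place of fluoro on an aromatic carbon), leads from compound 2 to compound 4.

Compound 4 is expected to behave much like its neighbours, because compound 2 gives > 307000 nM in this assay and compound 1 gives 308000 nM. The expected step is an at least 1.0-fold lower number from compound 2 to compound 4 (0.01 log units; that floor lies within the scatter), set beside the unreadable a step that the limit leaves unreadable from compound 1 to compound 3. Compound 4 is estimated at 300000 nM, most probably reported again only as a limit, within 150000 nM to 600000 nM.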

Compound 4, half-maximal cytotoxic concentration: > 298000 nM
Compound 4 gave a limit, no number; the forecaster's own chance of this, stated with the estimate: 80%; the middle value does not contradict the limit.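

In this assay compound 2 and compound 4 each give only a limit, not a number, and the step from fluoro to methoxy between them cannot be read. The compounds shown leave open where the true values of compound 2, compound 3 and compound 4 lie, and whether methoxy in place of fluoro on an aromatic carbon changes this read-out on either core.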